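The source may hold more compounds than are shown below. What is called first, only, known or untested is meant among the compounds shown, and "the series" means these compounds.

Among the measured compounds shown here, in a functional assay (liver) for inhibition, with Liver microsome (Rattus norvegicus) as the target, using microsomes (a lower number here means a stronger inhibitor, a higher number a weaker inhibitor), compound 2 (`CCCCCCNc1ccc(O)cc1`) gives 33 nM as the higher of the two numbers so far, while compound 1 (`CCCCCCCCCCCCNc1ccc(O)cc1`) gives 15.5 nM as the lower. Compound 3 (`CCCCCCCCNc1ccc(O)cc1`) differs from compound 2 by ethyl in place of hydrogen on a saturated chain carbon, six bonds along the chain from a nitrogen on an aromatic ring on the chain. For the measured compounds named here, one measured step bears on this: a 2.1-fold higher number from compound 1 to compound 2 (0.33 log units; beyond the scatter) where the chain is cut back. Adding ethyl reverses only part of that cut, so a smaller shift toward a lower number in this assay is expected, possibly within the scatter. The expected change is a 1.4-fold lower number from compound 2 to compound 3 (0.16 log units; within the scatter) as estimated here. For compound 3 the estimate is 23 nM with an expected range of 13 nM to 40 nM in this series.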

Compound 3, half-maximal inhibitory concentration: 14 nM
Compound 3: the middle estimate sits 1.6-fold (0.22 log units) above what was measured; measured number inside the range.
By their numbers in this assay, from the lowest: compounds 3 and 1 (each within the scatter of the next); then compound 2.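

In this assay, ethyl in place of hydrogen at this chain carbon gives a step beyond the scatter: a 2.4-fold lower number from compound 2 to compound 3 (0.37 log units; beyond the scatter). The further change at the chain, hydrogen in place of butyl eight bonds along from the nitrogen, stays within the scatter: a 1.1-fold lower number from compound 1 to compound 3 (0.04 log units; within the scatter), so the added length shows no gain past the octyl-length chain of compound 3 among these compounds. Nothing measured alongside these numbers bears on this result. Open, going by these compounds, is whether a longer chain stays at this level, and whether an amine or a carboxylic acid at the chain end is tolerated.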